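Swapping a sulfinyl chain for a sulfanyl chain on the shared core

This account rests on a few compounds, and the source may have more. Where it says the series, first, only, none or still open, it means among the compounds named here.

This study concerns inhibitors of an enzyme that breaks down prostaglandins, tested in an assay for inhibition of 15-hydroxyprostaglandin dehydrogenase [NAD(+)] (Homo sapiens), read by fluorescence, with a stated time of 15 min, in the presence of a further agent that is not named here; a higher number here means a weaker inhibitor, a lower number a stronger inhibitor. Compound 1, with the structure `CCC[S+]([O-])c1sc2nc(-c3cccs3)cc(-c3ccccc3)c2c1N`, gives 2.1 nM in this assay, the lowest of the two numbers recorded so far. Among the compounds with values here, the only comparison available is compound 2, `CCCC[S+]([O-])c1sc2nc(-c3nccs3)cc(-c3ccc(C(=O)N(C)C)cc3)c2c1N`, which gives 5.9 nM; its number is higher than that of compound 1 by more than the usual scatter, but the two compounds differ in several places at once, so no single-point step can be read from them.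

Compound 3, `CCCCSc1sc2nc(-c3cccs3)cc(-c3ccccc3)c2c1N`, has not yet been measured. It differs from compound 1 at a single point: a group of 5 heavy atoms (4 carbon, 1 sulfur; no ring) in place of a group of 5 heavy atoms (3 carbon, 1 oxygen, 1 sulfur; no ring), on an aromatic carbon. The group that leaves carries one oxygen; the group that enters, butylsulfanyl, does not, and it is one carbon longer.

Within the data shown here, with no measured step of this kind to lean on, the expectation for compound 3 is a modest weakening, with the change from compound 1 to compound 3 estimated at a 2.9-fold higher number from compound 1 to compound 3 (0.46 log units; beyond the scatter). The estimated value for compound 3 in this assay is 6 nM, within a range from 1.5 nM to 30 nM.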

Compound 3, half-maximal inhibitory concentration: > 80 nM
Compound 3 ended at the assay's limit; the forecaster's own chance of this, stated with the estimate: 2%; middle value at least 13-fold (1.12 log units) away from the limit.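

In this assay, compound 3 gives > 80 nM, which is a limit of the assay and not a number. The earlier pair differed in several places at once, whereas this single change, on an aromatic carbon next to the ring sulfur, gives an at least 38-fold higher number from compound 1 to compound 3 (1.58 log units; beyond the scatter), so this position clearly matters for inhibition of the enzyme. The two groups have the same number of heavy atoms and the same number of hydrogen-bond acceptors, so those counts alone do not decide the outcome here, and the full size of the step cannot be read from a result that rests on this limit: the limit of > 80 nM in this assay, at which 1 of the 3 values shown sits.

The compounds shown leave open whether the step comes from losing the oxygen on the chain sulfur or from adding the extra carbon, since both happen together in this one change; a propylsulfanyl chain or a butylsulfinyl chain on the core of compound 1 would separate the two. They also leave open how a propylsulfonyl chain, or a chain with no sulfur at all, such as pentyl, would behave at this position.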